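This account rests on a few compounds, and the source may have more. Where it says the series, first, only, none or still open, it means among the compounds named here.

Measured so far:
- compound 1 `CC(=O)c1ccc(NC(=O)C(C(C)C)N(C(=O)c2ccccc2)S(=O)(=O)c2ccc([N+](=O)[O-])cc2)cc1`: 6800000 nM
- compound 2 `CC(=O)c1ccc(NC(=O)CN(C(=O)c2ccccc2)S(=O)(=O)c2ccccc2)cc1`: 32000000 nM
- compound 3 `CCC(C)C(C(=O)Nc1ccc(C(C)=O)cc1)N(C(=O)c1ccccc1)S(=O)(=O)c1ccccc1`: 8600000 nM

In a functional assay, read by spectrophotometry, with a stated time of 20 min (a lower number here means a stronger inhibitor, a higher number a weaker inhibitor), compound 3 stands second highest of the three numbers; compound 1 lies within the scatter of it, while compound 2 lies beyond. Compound 4 `CC(=O)c1ccc(NC(=O)C(C(C)C)N(C(=O)c2ccccc2)S(=O)(=O)c2ccccc2)cc1` differs from compound 3 by hydrogen in place of methyl on a saturated chain carbon, three bonds along the chain from an amide-type nitrogen and a carbonyl carbon. Among the compounds with values here, the one step that bears on this place is a 3.7-fold lower number from compound 2 to compound 3 (0.57 log units; beyond the scatter), a modest change when the whole sec-butyl was added. Removing one methyl of it should cost at most a fraction of that, and compound 1, which carries isopropyl with a different sulfonyl, gives 6800000 nM, close to compound 3. Compound 4 is therefore expected to show a 1.2-fold higher number from compound 3 to compound 4 (0.07 log units; within the scatter), a small rise. The estimate for compound 4 in this assay is 10000000 nM, range 5000000 nM to 22000000 nM.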

Compound 4, half-maximal inhibitory concentration: 13000000 nM
For compound 4 the middle estimate is 1.3-fold (0.11 log units) below the measured one; the measured number falls inside the stated range.
By their numbers in this assay, from the lowest: compounds 1, 3 and 4 (each within the scatter of the next); then compound 2.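

Cutting sec-butyl back to isopropyl in this assay gives a 1.5-fold higher number from compound 3 to compound 4 (0.18 log units; within the scatter) and so leaves the removed methyl unresolved at this position. Isopropyl in place of hydrogen on the same carbon still gives a 2.5-fold lower number from compound 2 to compound 4 (0.39 log units; beyond the scatter) and so keeps the direction seen with sec-butyl. Hydrogen in place of nitro on an aromatic carbon gives a 1.9-fold higher number from compound 1 to compound 4 (0.28 log units; within the scatter) and is likewise unresolved.

No measurement available here speaks to the cause of these steps. On these data alone, whether an amine, a carboxylic acid or a longer chain on that saturated chain carbon would move the number further stays open.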